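The source may report more compounds than this note shows. Statements on the series, on what has been measured and on what is new or still open speak of the compounds shown alone.

In an in vitro ADME assay on microsomes from liver (Homo sapiens) for metabolic stability, tested at 5 uM (a lower number here means that the compound disappears faster, a higher number that the compound lasts longer), compound 1 (`CC(C)CCn1nc(-c2cccs2)c(O)c(C2=NS(=O)(=O)c3cc(NS(=O)(=O)C4CC4)ccc3N2)c1=O`) gives > 1 h as its result, and that is a limit of the assay, not a number. Compound 2 (`COCN(c1ccc2c(c1)S(=O)(=O)N=C(c1c(O)c(-c3cccs3)nn(CCC(C)C)c1=O)N2)S(C)(=O)=O`) gives 0.183 h as a true number. Compound 3 (`CC(C)CCn1nc(CC2CCC2)c(O)c(C2=NS(=O)(=O)c3cc(NS(C)(=O)=O)ccc3N2)c1=O`) gives 0.417 h as a true number, the higher of the two.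

In compound 4 (`CCC(C)(C)c1nn(CCC(C)C)c(=O)c(C2=NS(=O)(=O)c3cc(NS(C)(=O)=O)ccc3N2)c1O`) 1,1-dimethylpropyl stands in place of cyclobutylmethyl on an aromatic carbon (1,1-dimethylpropyl in place of cyclobutylmethyl on an aromatic carbon), and the rest matches compound 3. Among the measured compounds shown here, the only measured step, an at least 5.4-fold lower number from compound 1 to compound 2 (0.73 log units; beyond the scatter) as its full size, concerns a different group, so it does not bear directly on this change. For the measured compounds named here, it shows only that one change can move the half-life beyond the scatter, which argues for a wide range. Going by the values given here, no step at this place has been measured, so the expectation starts from compound 3 at 0.417 h with no direction favoured. The expected change is a 1.2-fold higher number from compound 3 to compound 4 (0.08 log units; within the scatter) and so stays within the scatter. The estimate for compound 4 is 0.5 h as a middle value, with 0.2 h to 1 h as the expected range.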

Compound 4, half-life: 0.1 h
For compound 4 the middle estimate is 5.0-fold (0.70 log units) above the measured one; the measured number lies below the stated range.
By their numbers in this assay, from the lowest: compounds 4 and 2 (each within the scatter of the next); then compound 3. At a limit, above all of these: compound 1.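

In this assay this position, on an aromatic carbon next to the ring nitrogen, shows a 4.2-fold lower number from compound 3 to compound 4 (0.62 log units; beyond the scatter) even though cyclobutylmethyl and 1,1-dimethylpropyl each hold 5 heavy atoms, all carbon. Among the compounds shown here, the only earlier step lay at a different place, the (cyclopropylsulfonyl)amino group, so this is the first sign that a change at this position can also move the half-life beyond the scatter, and that an equal count of heavy atoms does not keep it steady. Nothing at hand accounts for the drop.

For the compounds shown here, with only two groups compared here, it remains open whether losing the four-membered ring or the different shape of the chain matters more. As far as these compounds go, how a longer straight chain, an amine or a carboxylic acid at this position would behave also stays open.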